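Shifting a Hydroxyl Group: Expected Effect on HeLa Cytotoxicity

This account rests on a few compounds, and the source may have more. Where it says the series, first, only, none or still open, it means among the compounds named here.

Compound 1 `Oc1cccc(-c2cc(-c3ccoc3)cc(-c3ccccc3O)n2)c1`: in a functional assay on HeLa cells (Homo sapiens) for cytotoxicity, read by CCK-8 assay (on this read-out lower numbers stand for stronger inhibition and higher numbers for weaker inhibition), compound 1 gives > 50000 nM, which is a limit of the assay and not a number.
Compound 2 `Oc1cccc(-c2cc(-c3ccoc3)cc(-c3cccc(O)c3)n2)c1`: in this assay compound 2 gives 4630 nM.
Compound 3 `Oc1ccccc1-c1cc(-c2cccnc2)cc(-c2ccccc2O)n1`: in this assay compound 3 gives > 50000 nM, again a limit of the assay rather than a number.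

Compound 1 and compound 2 differ in one place: 3-hydroxyphenyl in place of 2-hydroxyphenyl on an aromatic carbon. That change brings an at least 10-fold lower number from compound 1 to compound 2 (1.03 log units; beyond the scatter). The step is known only as a lower bound because the limit of > 50000 nM in this assay, at which 2 of the 3 values shown sit, holds the value of compound 1.

Compound 4 `Oc1cccc(-c2cc(-c3cccnc3)cc(-c3ccccc3O)n2)c1` has not yet been tested in this assay. It is related to compound 3 by the same kind of change: 3-hydroxyphenyl in place of 2-hydroxyphenyl on an aromatic carbon. The surroundings are not identical, since in the first pair the changed group sits meta to a 3-hydroxyphenyl group and meta to a furan-3-yl group, while in the second pair it sits meta to a 2-hydroxyphenyl group and meta to a pyridin-3-yl group. How the core of compound 1 and the core of compound 3 differ is not broken down here.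

Given that compound 3 sits at the limit of this assay, and that the first pair moved from the limit to a measured number, compound 4 is expected to show an at least 5.5-fold lower number from compound 3 to compound 4 (0.74 log units; beyond the scatter). The estimate for compound 4 in this assay is 9000 nM, with a plausible range from 2500 nM to 50000 nM, resting on the step seen from compound 1 to compound 2.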

Compound 4, half-maximal inhibitory concentration: 7530 nM
Compound 4: the middle estimate sits 1.2-fold (0.08 log units) above what was measured; the range from low to high includes it.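

In this assay, putting 3-hydroxyphenyl in place of 2-hydroxyphenyl on a second core gives an at least 6.6-fold lower number from compound 3 to compound 4 (0.82 log units; beyond the scatter) and so points the same way as on the first core, which suggests that this change carries across the two cores shown: the same change on two cores in this assay, an at least 10-fold lower number (1.03 log units; beyond the scatter) from compound 1 to compound 2 and an at least 6.6-fold lower number (0.82 log units; beyond the scatter) from compound 3 to compound 4; the limit leaves it open whether they differ. As far as these compounds go, the true size of each step stays unknown, and the two sizes cannot be compared, because each step starts from a compound held at a limit of the assay rather than at a number: the limit of > 50000 nM in this assay, at which 2 of the 4 values shown sit. A different change, pyridin-3-yl in place of furan-3-yl, gives an at least 6.6-fold lower number from compound 1 to compound 4 (0.82 log units; beyond the scatter) and also starts from a limit, while two cores are too few to show that the hydroxyl shift would act the same way on every core in this series.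

The compounds shown leave open how a core carrying 3-hydroxyphenyl on both sides together with pyridin-3-yl would behave, which would put the second core on the same footing as compound 2. They also leave open whether the hydroxyl itself matters, which a methoxy group or an amine in its place on the same ring could test.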